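From Trifluoromethyl to Dimethoxy on the Aryl Amine

A few compounds are considered here, and "the series" means these few. Any claim that something is new, unique, unknown or untested is made for them only; others in the source may bear on it.

Compound 1, `CCCCCCCCCCCCNc1nc(SCc2ccc(C(F)(F)F)cc2)nc2ccccc12`: 38700 nM
Compound 2, `CCOc1ccccc1Nc1nc(SCc2ccc(C(F)(F)F)cc2)nc2ccccc12`: > 50000 nM
Compound 3, `FC(F)(F)c1ccc(CSc2nc(Nc3cccc(C(F)(F)F)c3)c3ccccc3n2)cc1`: 11700 nM

Three compounds share the core of compound 1 and were tested in a functional assay on HGC-27 cells (Homo sapiens) for cytotoxicity, read by MTT assay, with a stated time of 72 h; on this read-out lower numbers stand for stronger inhibition and higher numbers for weaker inhibition. Compound 3 gives 11700 nM, the lowest of the two numbers available. Compound 1 gives 38700 nM, a higher number. For compound 2 only a limit of the assay is reported, > 50000 nM, which is the limit of > 50000 nM in this assay, at which 1 of the 3 values shown sits.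

Within the data shown here, one measured step bears on the new compound: an at least 4.2-fold lower number from compound 2 to compound 3 (0.63 log units; beyond the scatter). That step replaced 2-ethoxyphenyl with 3-(trifluoromethyl)phenyl and brought the number down from the limit to a measurable value.

Compound 4, `COc1ccc(Nc2nc(SCc3ccc(C(F)(F)F)cc3)nc3ccccc23)cc1OC`, has not yet been measured. It differs from compound 3 as follows: 3,4-dimethoxyphenyl in place of 3-(trifluoromethyl)phenyl on a nitrogen on an aromatic ring. The change reverses the direction of the measured step in kind, putting an oxygen-bearing phenyl back where the trifluoromethyl-bearing one stood, much as in compound 2, though as 3,4-dimethoxyphenyl rather than 2-ethoxyphenyl.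

Compound 4 is therefore expected to give a higher number than compound 3, with a 2.6-fold higher number from compound 3 to compound 4 (0.41 log units; beyond the scatter) as the estimated step, because an at least 4.2-fold lower number from compound 2 to compound 3 (0.63 log units; beyond the scatter) went the other way. Compound 4 is estimated at 30000 nM, in a range from 9000 nM to 50000 nM.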

Compound 4, half-maximal inhibitory concentration: 17900 nM
Beside the measured number, compound 4's estimate is 1.7-fold (0.22 log units) above it, and the stated range covers the measured number.
By their numbers in this assay, from the lowest: compounds 3 and 4 (each within the scatter of the next); then compound 1. At a limit, above all of these: compound 2.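

The result shows that an oxygen-bearing phenyl on this nitrogen does not by itself return the number to the limit: in this assay, 3,4-dimethoxyphenyl in place of 3-(trifluoromethyl)phenyl gives a step within the scatter (a 1.5-fold higher number from compound 3 to compound 4 (0.18 log units; within the scatter)), and the two groups read alike here. A trifluoromethyl group on this phenyl is therefore not required for a measurable number, and the earlier step away from 2-ethoxyphenyl cannot be read as the work of trifluoromethyl alone. The two oxygen-bearing phenyl groups also differ from each other (an at least 2.7-fold lower number from compound 2 to compound 4 (0.44 log units; beyond the scatter)), a step that starts from a limit of the assay for compound 2: the limit of > 50000 nM in this assay, at which 1 of the 4 values shown sits.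

The compounds shown leave open whether that difference follows the place of the oxygen on the phenyl or the ethoxy chain itself, since 2-ethoxyphenyl and 3,4-dimethoxyphenyl differ in more than one respect. In this assay they also leave open how a phenyl carrying a carboxylic acid or a dimethylamino group would read on this nitrogen.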